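The compounds below may be only part of what the source reports. "The series", "measured", "known", "first", "only" and "open" are said of these compounds alone.

For the measured compounds named here, compound 2 `c1cn2cc(-c3ccsc3)nc(-c3ccc4ncn(C5CCCCC5)c4c3)c2n1` gives 19.9% in a functional assay on PC-3 cells (Homo sapiens) for inhibition, read by sulforhodamine B assay, with a stated time of 48 h, tested at 10 uM (a lower number here means less inhibition, a higher number more inhibition at the concentration tested (going by the name of the read-out)), the lower of the two numbers measured so far; compound 1 `Fc1ccc(-c2cn3ccnc3c(-c3ccc4ncn(C5CCCCC5)c4c3)n2)cc1` gives 53.6% in this assay. Going by the values given here, the one measured step, a number 33.7 percentage points lower from compound 1 to compound 2 (beyond the scatter), is the only one that bears on the change ahead. Compound 3 `Clc1ccc(-c2cn3ccnc3c(-c3ccc4ncn(C5CCCCC5)c4c3)n2)cc1` differs from compound 2 by 4-chlorophenyl in place of thiophen-3-yl on an aromatic carbon, bringing back a halogen-bearing phenyl akin to the 4-fluorophenyl of compound 1. Because a number 33.7 percentage points lower from compound 1 to compound 2 (beyond the scatter) was large, a rise of similar size is expected on the way back, so the estimated step is a number 30.1 percentage points higher from compound 2 to compound 3 (beyond the scatter). Compound 3 is therefore estimated at 50%, within 30% to 70%.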

Compound 3, a percentage reported as inhibition, at one concentration (the size of the read-out at that concentration, not a potency): 24.6%
Estimate against measurement, compound 3: 25.4 percentage points above, outside the stated range (below it).
By their numbers in this assay, from the lowest: compounds 2 and 3 (each within the scatter of the next); then compound 1.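

At this position, with the shared core unchanged, a halogen on the phenyl ring does not by itself give the higher number in this assay: chloro in place of fluoro cuts it (a number 29 percentage points lower from compound 1 to compound 3 (beyond the scatter)). The 4-chlorophenyl and thiophen-3-yl groups are not separated (a number 4.7 percentage points higher from compound 2 to compound 3 (within the scatter)), so among these three compounds only the 4-fluorophenyl of compound 1 stands apart. Nothing available accounts for the gap between fluoro and chloro.

The compounds shown leave open how an unsubstituted phenyl would read on this aromatic carbon. As far as these compounds go, a 4-methoxyphenyl or 4-aminophenyl group is equally open.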